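The compounds below may be only part of what the source reports. "The series", "measured", "known", "first", "only" and "open" are said of these compounds alone.

Measured so far:
compound 1 `COc1ccccc1C(=O)NC(=O)Nc1ccc(-c2nccs2)c(C(F)(F)F)c1` — 33 mL.min-1.g-1
compound 2 `COc1ccncc1C(=O)NC(=O)Nc1ccc(-c2ccccc2)c(C(F)(F)F)c1` — < 14 mL.min-1.g-1

Within the data shown here, in an in vitro ADME assay on microsomes from liver (Rattus norvegicus) for metabolic stability, with a stated time of 30 min (a lower number here means slower removal, a higher number faster removal of the compound), compound 1 gives 33 mL.min-1.g-1, the only numerical value in the set. Compound 2 is reported only at a limit of the assay, < 14 mL.min-1.g-1, which is the limit of < 14 mL.min-1.g-1 in this assay, at which 1 of the 2 values shown sits. Among the measured compounds shown here, no step between two measured compounds is available, so the standing of compound 1 rests on this single number alone.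

Compound 3 `COc1ccccc1C(=O)NC(=O)Nc1ccc(C(C)C)c(C(F)(F)F)c1` is not yet measured in this assay. It differs from compound 1 by isopropyl in place of 1,3-thiazol-2-yl on an aromatic carbon; the isopropyl sits on an aromatic carbon of a six-membered aromatic ring of carbon only, ortho to the trifluoromethyl group and para to a large group. For the measured compounds named here, with no comparable step in the set, the direction is open; a modest rise in clearance is expected, though a result within the scatter of compound 1 would not surprise. For compound 3 a value of 45 mL.min-1.g-1 is estimated, between 18 mL.min-1.g-1 and 110 mL.min-1.g-1. This implies an expected step of a 1.4-fold higher number from compound 1 to compound 3 (0.13 log units; within the scatter).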

Compound 3, intrinsic clearance in microsomes in the Rattus norvegicus assay: < 14 mL.min-1.g-1
Compound 3: a limit, no number (the forecaster's own chance of this, stated with the estimate: 12%); middle value at least 3.2-fold (0.50 log units) away from the limit.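

Among these compounds, at this position, on an aromatic carbon ortho to a trifluoromethyl group, the earlier compounds offered no step. From the compounds shown here alone, in the Rattus norvegicus assay, isopropyl in place of 1,3-thiazol-2-yl now gives an at least 2.3-fold lower number from compound 1 to compound 3 (0.37 log units; beyond the scatter), so the thiazole is not needed for the low read-out, and the true size of the step stays unknown, since compound 3 is reported only at a limit: the limit of < 14 mL.min-1.g-1 in the Rattus norvegicus assay, at which 2 of the 3 values shown sit. In a physicochemical assay for solubility, in phosphate buffer, at pH 7.4 (on this read-out lower numbers stand for lower solubility and higher numbers for higher solubility), compound 1 gives < 1 ug/mL as a limit. In the physicochemical assay, compound 3 gives < 1 ug/mL as a limit. No step can be read there: the limit of < 1 ug/mL in the physicochemical assay, at which 2 of the 2 values shown sit.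

Going by these compounds, how far compound 3 lies past its limit remains open. Also open, on these data alone, is whether a longer chain or an amine on the same aromatic carbon would stay at that limit, or would lift the values off the limit in the physicochemical assay.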